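Swapping Phenyl for Phenethyl on Two Different Cores

A few compounds are considered here, and "the series" means these few. Any claim that something is new, unique, unknown or untested is made for them only; others in the source may bear on it.

Compound 1 `Nc1cc(Cl)c(Cl)cc1C1=NN(C(=O)c2ccccc2)CC1` and compound 2 `Nc1cc(Cl)c(Cl)cc1C1=NN(C(=O)CCc2ccccc2)CC1` share one core and differ in a single place: phenethyl in place of phenyl on a carbonyl carbon. In an assay on isolated protein for inhibition of Nitric oxide synthase, inducible (Homo sapiens), with a stated time of 30 min, tested at 1 mM (a lower number here means less inhibition, a higher number more inhibition at the concentration tested (going by the name of the read-out)), compound 1 gives 36.1%, and compound 2 gives 50.2%. The step is a number 14.1 percentage points higher from compound 1 to compound 2 (beyond the scatter). Compound 3 `COc1cc(N)c(C2=NN(C(=O)c3ccccc3)CC2)c(OC)c1OC` is built on a different core; how the two cores differ is not broken down here. In this assay compound 3 gives 8.14%, the lowest of the three numbers. Compound 4 `COc1cc(N)c(C2=NN(C(=O)CCc3ccccc3)CC2)c(OC)c1OC` has not yet been measured and differs from compound 3 by the same change at the same place: phenethyl in place of phenyl on a carbonyl carbon. Because the earlier step was a number 14.1 percentage points higher from compound 1 to compound 2 (beyond the scatter), a step of similar direction but somewhat smaller size is expected here, since compound 3 starts from a low number. The expected step is a number 9.9 percentage points higher from compound 3 to compound 4 (within the scatter). For compound 4 the estimate in this assay is 18%, most likely between 5% and 35%.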

Compound 4, a percentage reported as inhibition, at one concentration (the size of the read-out at that concentration, not a potency): 18.3%
Beside the measured number, compound 4's estimate is 0.3 percentage points below it; measured number inside the range.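

Phenethyl in place of phenyl on a carbonyl carbon gives a number 10.2 percentage points higher from compound 3 to compound 4 (beyond the scatter) in this assay. Set beside the step on the other core, the change agrees in direction and in size: the same change on two cores in this assay, a number 14.1 percentage points higher (beyond the scatter) from compound 1 to compound 2 and a number 10.2 percentage points higher (beyond the scatter) from compound 3 to compound 4, 3.9 percentage points apart, within the scatter of two such steps

In these two pairs, then, the change carries over from one core to the other, but two pairs do not show that it would do so on a further core, and they do not explain why the number rises.

The compounds shown leave open how the number would respond to a benzyl group or a longer chain on the same carbonyl carbon. They also leave open what an amine or a carboxylic acid at the end of that chain would do.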